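The compounds below may be only part of what the source reports. "The series", "measured", "known", "first", "only" and "open" are said of these compounds alone.

Compounds measured in a functional assay on the whole organism with Rattus norvegicus as the target; on this read-out higher numbers stand for an effect only at larger amounts of compound and lower numbers for an effect already at smaller amounts

- compound 1 `N#CCn1c(=N)sc2cc(OC(F)(F)F)ccc21` gives 3.5 mg/kg
- compound 2 `N=c1sc2cc(OC(F)(F)F)ccc2n1CC(=O)O` gives > 10 mg/kg as a limit of the assay
- compound 3 `N=c1sc2cc(OC(F)(F)F)ccc2n1CCS(N)(=O)=O` gives 6 mg/kg

Compound 3 lies within the scatter of compound 1 (a 1.7-fold higher number from compound 1 to compound 3 (0.23 log units; within the scatter)). Against compound 2 only a floor is known (an at least 1.6-fold lower number from compound 2 to compound 3 (0.22 log units; that floor lies within the scatter)). Compound 4 `CNS(=O)(=O)CCn1c(=N)sc2cc(OC(F)(F)F)ccc21` carries methyl in place of hydrogen on a sulfonamide nitrogen. For the measured compounds named here, no measured step touches that nitrogen. Going by the values given here, the nearest evidence concerns the chain end, where carboxy in place of cyano gave the only step beyond the scatter (an at least 2.8-fold higher number from compound 1 to compound 2 (0.45 log units; beyond the scatter)). No step beyond the scatter is therefore expected in this assay, the expected one being no change at the digits printed from compound 3 to compound 4 (within the scatter) as a whole. Compound 4 is estimated at 6 mg/kg within an expected range (3 mg/kg to 12 mg/kg).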

Compound 4, dose for half-maximal effect: 4 mg/kg
Compound 4: the middle estimate sits 1.5-fold (0.18 log units) above what was measured; measured number inside the range.
By their numbers in this assay, from the lowest: compounds 1, 4 and 3 (each within the scatter of the next). At a limit, above all of these: compound 2.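

Methyl in place of hydrogen on a sulfonamide nitrogen, a place no earlier step touched, stays within the scatter in this assay, with a 1.5-fold lower number from compound 3 to compound 4 (0.18 log units; within the scatter), and the methylated compound also stays within the scatter of the nitrile, with a 1.1-fold higher number from compound 1 to compound 4 (0.06 log units; within the scatter). Against the carboxy compound, the floor now lies beyond the scatter, with an at least 2.5-fold lower number from compound 2 to compound 4 (0.39 log units; beyond the scatter), which the floor for compound 3 did not. That step rests on a limit of the assay for compound 2, not a number: the limit of > 10 mg/kg in this assay, at which 1 of the 4 values shown sits.

From the compounds shown here alone, whether an ethyl group or a second methyl on that nitrogen would stay within the scatter remains open. So does the effect of a longer chain carrying the sulfonamide.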